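Trimming the Sulfonamide of Compound 2

The compounds below may be only part of what the source reports. "The series", "measured", "known", "first", "only" and "open" are said of these compounds alone.

In a functional assay on UO-31 cells (Homo sapiens) for antiproliferative activity, read by sulforhodamine B assay, with a stated time of 72 h (a lower number here means a stronger inhibitor, a higher number a weaker inhibitor), compound 2 `O=S(=O)(Nc1nccs1)c1ccc(Nc2nncc3ccccc23)cc1` gives 12 nM. That lies within the usual scatter of compound 1 `Clc1ccc(C(/C=C/c2ccccc2)=N\Nc2nncc3ccccc23)cc1` at 6.2 nM, and it is a lower number, beyond the scatter, than compound 3 `O=C1CS/C(=N/Nc2nncc3ccccc23)N1` at 25 nM. Compound 4 `NS(=O)(=O)c1ccc(Nc2nncc3ccccc23)cc1` has hydrogen in place of 1,3-thiazol-2-yl on a sulfonamide nitrogen. Within the data shown here, no measured pair shows this change on its own, so the data give no direct guide to its size. A modest move towards a higher number is expected, landing near compound 3 at 25 nM. The estimated change is a 1.7-fold higher number from compound 2 to compound 4 (0.22 log units; within the scatter). For compound 4 the estimated value is 20 nM, with an expected range from 6 nM to 70 nM.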

Compound 4, half-maximal inhibitory concentration: 23 nM
The estimate for compound 4 lay 1.2-fold (0.06 log units) below the measured number; measured number inside the range.
By their numbers in this assay, from the lowest: compounds 1, 2, 4 and 3 (each within the scatter of the next, the first and the last beyond it).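

Replacing 1,3-thiazol-2-yl with hydrogen on the sulfonamide nitrogen gives in this assay a 1.9-fold higher number from compound 2 to compound 4 (0.28 log units; within the scatter) and so this five-membered aromatic ring can be removed entirely without a step beyond the scatter. This is the first pair among these compounds to differ in one place, and it shows that the plain sulfonamide of compound 4 still reads in the same range as compound 2. Nothing measured here accounts for this step.

On these data alone, what a methyl group or a phenyl ring on the same nitrogen would give remains open.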